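Swapping Methyl for Chloro at Compound 4

This account rests on a few compounds, and the source may have more. Where it says the series, first, only, none or still open, it means among the compounds named here.

Of the compounds shown here, three sharing one core have been measured in a functional assay, with a stated time of 30 min; a higher number here means a weaker inhibitor, a lower number a stronger inhibitor. Compound 1 `Oc1ccc(O)c(/C=N/c2ccc(OCc3ccccc3)cc2)c1` gives 21300 nM. Compound 2 `Oc1cccc(/C=N/c2ccc(OCc3ccccc3)cc2)c1O` gives 13300 nM. From the compounds shown here alone, compound 3 `Cc1ccc(O)c(/C=N/c2ccc(OCc3ccccc3)cc2)c1` gives only a limit of the assay, > 200000 nM, so its exact position is unknown. The step of a 1.6-fold lower number from compound 1 to compound 2 (0.20 log units; within the scatter) stays within the scatter, while an at least 9.3-fold higher number from compound 1 to compound 3 (0.97 log units; beyond the scatter) and an at least 15-fold higher number from compound 2 to compound 3 (1.17 log units; beyond the scatter) both move beyond it, so compound 3 sits at the weak end of the three, resting at the limit (the limit of > 200000 nM in this assay, at which 1 of the 3 values shown sits).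

Compound 4 `Oc1ccc(Cl)cc1/C=N/c1ccc(OCc2ccccc2)cc1` is not yet measured. It differs from compound 3 by chloro in place of methyl on an aromatic carbon. Among the measured compounds shown here, none of the measured steps exchanges methyl for chloro; the two steps that reach compound 3 replace a hydroxy or a dihydroxyphenyl with a methyl-bearing group. They show that losing a hydroxy on that ring weakens inhibition, but they say nothing about whether chloro restores it. The step of an at least 1.3-fold lower number from compound 3 to compound 4 (0.12 log units; that floor lies within the scatter) is therefore expected to be small, and another limit is considered likely. Compound 4 is expected to give 150000 nM, between 40000 nM and 500000 nM, in this assay.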

Compound 4, half-maximal inhibitory concentration: > 200000 nM
Compound 4: no number, only a limit; the forecaster's own chance of this, stated with the estimate: 55%; middle value at least 1.3-fold (0.12 log units) from the limit.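

Chloro, para to a hydroxy group, brings no measurable inhibition back where methyl had lost it: compound 4 also rests at a limit of the assay, so the step from compound 3 cannot be read. In this assay, the loss therefore does not belong to methyl alone, as the chloro compound shows an at least 9.3-fold higher number from compound 1 to compound 4 (0.97 log units; beyond the scatter) and also an at least 15-fold higher number from compound 2 to compound 4 (1.17 log units; beyond the scatter). Two different groups at this position now share one ceiling of the measurement, and compound 3 and compound 4 cannot be told apart there: the limit of > 200000 nM in this assay, at which 2 of the 4 values shown sit.

From the compounds shown here alone, how far beyond that limit compound 3 and compound 4 lie remains unknown, so methyl and chloro cannot be ranked. Going by these compounds, whether an amine or a methoxy group at this position would keep inhibition in the range of compound 1 also stays open.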